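Replacing a hydroxyphenyl with benzyl on a ring nitrogen

The compounds below may be only part of what the source reports. "The series", "measured", "known", "first", "only" and "open" are said of these compounds alone.

Measured compounds:
Compound 1 `Cc1ccc(C)n1-c1cccc(-c2nnn[nH]2)c1`: 250000 nM
Compound 2 `CCOC(=O)C(=Cc1cc(C)n(-c2cccc(-c3nnn[nH]3)c2)c1C)C(=O)OCC`: 77400 nM
Compound 3 `Cc1cc(/C=C2\SC(=S)N(c3cccc(O)c3)C2=O)c(C)n1-c1cccc(-c2nnn[nH]2)c1`: 35600 nM

Of the compounds shown here, three sharing a common core have been tested in an ADME assay on MT2 cells (Homo sapiens) for cytotoxicity, read by XTT assay, with a stated time of 4 days; on this read-out higher numbers stand for lower toxicity in this test and lower numbers for higher toxicity in this test. Compound 1 gives 250000 nM, compound 2 gives 77400 nM, and compound 3 gives 35600 nM. Compound 3 thus stands lowest of the three numbers, that is, the most toxic in this assay; its nearest neighbour is compound 2, and compound 1 lies furthest from it, both gaps beyond the scatter.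

The next compound, compound 4 `Cc1cc(/C=C2\SC(=S)N(Cc3ccccc3)C2=O)c(C)n1-c1cccc(-c2nnn[nH]2)c1`, differs from compound 3 at one place:

benzyl in place of 3-hydroxyphenyl on an amide-type nitrogen in a ring

Within the data shown here, no pair of measured compounds that differ in a single place is available to gauge this change, so any expectation rests on the three values alone. The estimate is anchored on compound 3 because of 35600 nM. The change is expected to bring either no step beyond the scatter or a small move toward a lower number in this assay. The estimated step from compound 3 to compound 4 is a 1.3-fold lower number from compound 3 to compound 4 (0.10 log units; within the scatter). Compound 4 is therefore expected to give about 28000 nM, within the range 9000 nM to 90000 nM.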

Compound 4, half-maximal cytotoxic concentration: 150000 nM
Compound 4: middle estimate off by 5.4-fold (0.73 log units), on the low side; the whole stated range lies below it.
By their numbers in this assay, from the lowest: compound 3; then compounds 2, 4 and 1 (each within the scatter of the next, the first and the last beyond it).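

In this assay, among these compounds, the group on the amide-type nitrogen in the ring is the first place where a single change can be read, and benzyl in place of 3-hydroxyphenyl gives a 4.2-fold higher number from compound 3 to compound 4 (0.62 log units; beyond the scatter) in the direction of lower toxicity in this test. The number therefore responds to this position, even though the group that leaves and the group that enters each hold one six-membered aromatic ring of carbon only and the same count of heavy atoms. The change also removes one hydrogen-bond donor and one hydrogen-bond acceptor, but nothing measured here shows why the number moves.

The compounds shown leave open whether the step follows the loss of the hydroxyl or the carbon link that benzyl adds, as these two differences arrive together. A plain phenyl on this nitrogen would separate them, while a carboxylic acid or an amine on the benzyl ring would show how far this position tolerates other groups.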